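This account rests on a few compounds, and the source may have more. Where it says the series, first, only, none or still open, it means among the compounds named here.

Compound 1 `COc1cc(OCc2cccc(-c3ccc(OC)nc3)c2)c2cc(-c3cn4nc(OC)sc4n3)oc2c1` sits lowest of the three numbers in an ADME assay on microsomes from liver (Homo sapiens) for metabolic stability (on this read-out higher numbers stand for a longer-lived compound and lower numbers for a shorter-lived compound), where compound 1 gives 0.733 h. Within the data shown here, compound 2 `CNC(=O)c1ccc(-c2nc(COc3cc(OC)cc4oc(-c5cn6nc(OC)sc6n5)cc34)cs2)cc1` gives 0.983 h, and compound 3 `COc1cc(OCc2csc(-c3ccc(C(N)=O)cc3)n2)c2cc(-c3cn4nc(OC)sc4n3)oc2c1` gives 1.38 h; the one measured step, a 1.4-fold higher number from compound 2 to compound 3 (0.15 log units; within the scatter), stays within the scatter, as does every gap among the three. Compound 4 `COc1ccc(-c2cccc(COc3cc(OC)cc4oc(-c5cn6nc(OC)sc6n5)cc34)c2)nc1` differs from compound 1 by 5-methoxypyridin-2-yl in place of 6-methoxypyridin-3-yl on an aromatic carbon. Among the measured compounds shown here, no measured step touches this change: the step from compound 2 to compound 3 concerns an amide nitrogen elsewhere on the shared core, so it offers no guidance beyond showing that small edits left this assay unmoved. Compound 4 is therefore expected to show a 1.0-fold higher number from compound 1 to compound 4 (0.01 log units; within the scatter), a step not beyond the scatter, and is estimated at 0.75 h, between 0.4 h and 1.5 h.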

Compound 4, half-life: 0.767 h
The estimate for compound 4 lay 1.0-fold (0.01 log units) below the measured number, within the range that was stated.
By their numbers in this assay, from the lowest: compounds 1, 4, 2 and 3 (each within the scatter of the next).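

The change from 6-methoxypyridin-3-yl to 5-methoxypyridin-2-yl on an aromatic carbon gives a 1.0-fold higher number from compound 1 to compound 4 (0.02 log units; within the scatter) in this assay and so stays within the scatter. Among these compounds, at this place, meta to a large group, the two methoxypyridine isomers therefore cannot be told apart on this read-out, which the earlier compounds, with no step at this group, could not show. No evidence bears on why this exchange leaves the number within the scatter. On these data alone, it remains open whether a phenyl ring carrying a carboxylic acid or an amine in place of either methoxypyridine would move the number in this assay beyond the scatter.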